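Dimethylamino for chloro on the aryl hydrazone arm

The source may report more compounds than this note shows. Statements on the series, on what has been measured and on what is new or still open speak of the compounds shown alone.

Going by the values given here, compound 1 `O=C(N/N=C/c1ccc(Cl)cc1)c1cccnc1Nc1cccc(C(F)(F)F)c1` is one of two compounds measured in a functional assay on the whole organism (strain Wistar) for inhibition, with Rattus norvegicus as the target, read by paw edema, with a stated time of 30 min, at a dose of 10 mg/kg by the intraperitoneal route (on this read-out lower numbers stand for less inhibition and higher numbers for more inhibition at the one dose given (going by the name of the read-out)), where compound 1 gives 52.4%. Among the compounds with values here, its companion, compound 2 `COc1cccc(/C=N/NC(=O)c2cccnc2Nc2cccc(C(F)(F)F)c2)c1`, gives 52.8% in this assay, and the only measured step, a number 0.4 percentage points higher from compound 1 to compound 2 (within the scatter), shows that swapping the aryl group on the carbon with a double bond to nitrogen left the read-out within the scatter. Compound 3 `CN(C)c1ccc(/C=N/NC(=O)c2cccnc2Nc2cccc(C(F)(F)F)c2)cc1` differs from compound 1 by dimethylamino in place of chloro on an aromatic carbon. No measured step covers this particular exchange; the one step that exists concerns the same aryl position and was a number 0.4 percentage points higher from compound 1 to compound 2 (within the scatter), so an edit at that position is not shown to move the read-out. Compound 3 is therefore expected to give a number within the scatter of compound 1, the step of a number 2.4 percentage points lower from compound 1 to compound 3 (within the scatter) being the estimate. For compound 3 the estimate in this assay is 50%, with a range of 36% to 64%.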

Compound 3, a percentage reported as inhibition, in the whole organism at one dose (the size of the read-out at that dose, not a potency): 61.3%
The estimate for compound 3 lay 11.3 percentage points below the measured number, and the stated range covers the measured number.
By their numbers in this assay, from the lowest: compounds 1, 2 and 3 (each within the scatter of the next).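

In this assay, dimethylamino in place of chloro on an aromatic carbon gives a number 8.9 percentage points higher from compound 1 to compound 3 (within the scatter), and 4-(dimethylamino)phenyl in place of 3-methoxyphenyl gives a number 8.5 percentage points higher from compound 2 to compound 3 (within the scatter), so both new steps stay within the scatter. The aryl position therefore now carries a nitrogen-bearing group in place of chlorine, and the read-out at this one dose does not stand apart from that of the other two compounds. Nothing available here bears on why the read-out of compound 3 stands where it does.

Going by these compounds, whether a carboxylic acid or a longer chain on this aromatic carbon would also stay within the scatter remains open. So does the effect of changing the trifluoromethyl group or any other part of the shared core.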